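Phenoxy variation on a diaminoquinoxaline growth-inhibitor series

The compounds below may be only part of what the source reports. "The series", "measured", "known", "first", "only" and "open" are said of these compounds alone.

Compound 1 `Nc1cc(N)c2nc(-c3ccccc3)c(Oc3ccc(Cl)c(Cl)c3)nc2c1` carries a 3,4-dichlorophenoxy group on the shared core. In a functional assay on HCT-15 cells (Homo sapiens) for inhibition, read by sulforhodamine B assay, with a stated time of 48 h (on this read-out higher numbers stand for weaker inhibition of growth and lower numbers for stronger inhibition of growth), compound 1 gives only a limit, < 100000 nM, and no number. The two analogues with measured numbers sit in the weak range: compound 2 `CCOC(=O)[C@H](CCC(=O)O)NC(=O)c1ccc(Sc2nc3cc(N)cc(N)c3nc2-c2ccccc2)cc1` gives 42700 nM in this assay, and compound 3 `COc1ccc(CNc2nc3cc(N)cc(N)c3nc2-c2ccccc2)cc1` gives 34700 nM; these two values lie within the usual scatter of each other. Compound 4 `Nc1cc(N)c2nc(-c3ccccc3)c(Oc3ccc(F)cc3)nc2c1` differs from compound 1 by 4-fluorophenyl in place of 3,4-dichlorophenyl on an oxygen on an aromatic ring. Among the compounds with values here, no measured pair isolates this change, and the limit of < 100000 nM in this assay, at which 1 of the 3 values shown sits, fixes no size for it, so the step from compound 1 to compound 4 is expected to be a step that the limit leaves unreadable from compound 1 to compound 4, with no direction beyond scatter claimed. Compound 4 is estimated at 45000 nM, in the range 15000 nM to 100000 nM.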

Compound 4, concentration for total growth inhibition: < 100000 nM
Compound 4: no number, only a limit (the forecaster's own chance of this, stated with the estimate: 25%); the middle value lies beyond the limit too.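

Within the data shown here, compound 1 and compound 4 each give only a limit in this assay, so no step between them can be read: the limit of < 100000 nM in this assay, at which 2 of the 4 values shown sit.

Going by these compounds, whether 4-fluorophenyl and 3,4-dichlorophenyl on the oxygen differ at all in this assay stays open.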